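From bromo to hydroxy in compound 4

The compounds below may be only part of what the source reports. "The series", "measured", "known", "first", "only" and "open" are said of these compounds alone.

compound 1 `COc1ccc(C(=O)c2ccc(OC)c3c2OC(C)(C)C=C3)c(NC(=O)CBr)c1` gives 980 nM
compound 2 `COc1ccc(C(=O)c2ccc(OC)c3c2C=CC(C)(C)O3)c(NC(=O)CBr)c1` gives 2150 nM
compound 3 `COc1ccc(C(=O)c2ccc(OC)c3c2OC(C)(C)C=C3)c(NC(=O)CO)c1` gives 100 nM

In a functional assay on A2780 cells (Homo sapiens) for antiproliferative activity, read by MTT assay, with a stated time of 48 h (on this read-out lower numbers stand for stronger inhibition and higher numbers for weaker inhibition), compound 2 stands at 2150 nM as the highest of the three numbers, with both other compounds lower beyond the scatter. Compound 4 `COc1ccc(C(=O)c2ccc(OC)c3c2C=CC(C)(C)O3)c(NC(=O)CO)c1` departs from compound 2 by one change, hydroxy in place of bromo on a saturated chain carbon bound to a carbonyl carbon on the chain of the amide. Within the data shown here, one measured step bears on this, the same exchange on the core of compound 1, which gave a 9.8-fold lower number from compound 1 to compound 3 (0.99 log units; beyond the scatter) in that pair. It is a single precedent on a different core, so the transfer is uncertain. A step of similar size towards a lower number is expected in this assay and is estimated as a 9.3-fold lower number from compound 2 to compound 4 (0.97 log units; beyond the scatter) here. Compound 4 is expected at 230 nM within an estimated range of 80 nM to 700 nM in this read-out.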

Compound 4, half-maximal inhibitory concentration: 420 nM
Compound 4: middle estimate off by 1.8-fold (0.26 log units), on the low side; measured number inside the range.
By their numbers in this assay, from the lowest: compound 3; then compound 4; then compound 1; then compound 2.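

In this assay hydroxy in place of bromo on a saturated chain carbon bound to a carbonyl carbon again comes with a 5.1-fold lower number from compound 2 to compound 4 (0.71 log units; beyond the scatter) and so the exchange no longer rests on the core of compound 1 alone. The two cores agree in direction and, within the scatter, in size: the same change on two cores in this assay, a 9.8-fold lower number (0.99 log units; beyond the scatter) from compound 1 to compound 3 and a 5.1-fold lower number (0.71 log units; beyond the scatter) from compound 2 to compound 4, 1.9-fold (0.28 log units) apart, within the scatter of two such steps

The compounds shown leave open whether hydroxy is special here or whether an amine or a carboxylic acid on the same chain carbon would read alike. They also leave open whether a longer chain carrying the hydroxy would keep the lower number.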